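Swapping Bromine for Fluorine on a Weak Cytotoxic Sulfone

This account rests on a few compounds, and the source may have more. Where it says the series, first, only, none or still open, it means among the compounds named here.

Three compounds share one core and differ only in the halogens on their two aromatic rings. Compound 1 `CC(O)(CS(=O)(=O)c1ccc(F)cc1)c1nc(-c2ccc(Cl)cc2)no1` was tested in a functional assay on DU-145 cells (Homo sapiens) for cytotoxicity, read by MTT assay (a higher number here means a weaker inhibitor, a lower number a stronger inhibitor), and its result is a limit of the assay: compound 1 gives > 100000 nM. Compound 2 `CC(O)(CS(=O)(=O)c1ccc(Cl)cc1)c1nc(-c2ccc(Cl)cc2)no1` likewise gives only a limit, > 100000 nM. The step that the two limits leave unreadable from compound 1 to compound 2 therefore cannot be sized, and the limit of > 100000 nM in this assay, at which 2 of the 3 values shown sit, marks where both sit. Going by the values given here, compound 3 `CC(O)(CS(=O)(=O)c1ccc(Br)cc1)c1nc(-c2ccc(F)c(Cl)c2)no1` is the only one with a measured number: in this assay compound 3 gives 75000 nM, a weak inhibition. Compound 4 `CC(O)(CS(=O)(=O)c1ccc(F)cc1)c1nc(-c2ccc(F)c(Cl)c2)no1` differs from compound 3 by fluoro in place of bromo on an aromatic carbon. Compound 1 carries the same fluoro group on that ring, and in this assay compound 1 reached only its limit. Among the compounds with values here, no measured step reads the bromo-to-fluoro change directly, so the expected step of a 1.6-fold higher number from compound 3 to compound 4 (0.20 log units; within the scatter) is small and, if anything, toward weaker inhibition. Compound 4 is expected to give about 120000 nM, within 50000 nM to 300000 nM, with a fair chance of only a limit.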

Compound 4, half-maximal inhibitory concentration: > 100000 nM
Compound 4 ended at the assay's limit; the forecaster's own chance of this, stated with the estimate: 60%; the middle value is on the limit's open side.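

Replacing bromo with fluoro on this ring, para to a large group, gives an at least 1.3-fold higher number from compound 3 to compound 4 (0.12 log units; that floor lies within the scatter) in this assay. Going by these compounds alone, this is the first comparison to start from a measured number, yet it gives only a floor, and that floor does not separate compound 4 from compound 3, so the true size of the step stays unknown. The steps that join two limits cannot be read, and the set now gathers at one end of the scale: the limit of > 100000 nM in this assay, at which 3 of the 4 values shown sit.

From the compounds shown here alone, it remains open whether the true number of compound 4 lies close to that of compound 3 or far from it, and whether chloro on this ring would give a readable value. Also open, going by these compounds, is whether an amine or a carboxylic acid in place of the halogen would bring clear activity in this assay.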